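Bromo for Fluoro: Expected Cytotoxicity of Compound 4

The source may report more compounds than this note shows. Statements on the series, on what has been measured and on what is new or still open speak of the compounds shown alone.

Measured so far in an ADME assay on cells (Macrophage, Mus musculus) for cytotoxicity, read by resazurin assay, with a stated time of 3 days; on this read-out lower numbers stand for stronger inhibition and higher numbers for weaker inhibition:
compound 1 `O=C(Nc1cccc(F)c1)c1cc(Cl)ccc1O` gives 15000 nM
compound 2 `O=C(Nc1cccc(Br)c1)c1cc(Cl)ccc1O` gives 5700 nM
compound 3 `O=C(Nc1ccc(F)cc1C(F)(F)F)c1cc(Cl)ccc1O` gives 13000 nM

Compound 1 and compound 2 differ in one place only, (bromo in place of fluoro on an aromatic carbon). This change gave a 2.6-fold lower number from compound 1 to compound 2 (0.42 log units; beyond the scatter) in this assay, so the bromo compound came out with the lower number, meaning stronger inhibition of the cells.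

Compound 3 carries a different core: the difference between the core of compound 3 and the core of compound 1 is not broken down here. Its value in this assay is close to that of compound 1 and beyond the scatter away from that of compound 2.

Compound 4 `O=C(Nc1ccc(Br)cc1C(F)(F)F)c1cc(Cl)ccc1O` has not yet been measured. It differs from compound 3 by bromo in place of fluoro on an aromatic carbon. Within the data shown here, this is the same kind of change as the one from compound 1 to compound 2, though the surroundings are not identical: in compound 1 the place is meta to a large group, whereas in compound 3 it is meta to a trifluoromethyl group and para to a large group.

Because a 2.6-fold lower number from compound 1 to compound 2 (0.42 log units; beyond the scatter) was seen for the earlier pair, a step of a similar size is expected for compound 4 in this assay, namely a 2.4-fold lower number from compound 3 to compound 4 (0.37 log units; beyond the scatter). On this basis compound 4 is estimated at 5500 nM, with a likely range from 2500 nM to 12000 nM.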

Compound 4, half-maximal inhibitory concentration: 11000 nM
Beside the measured number, compound 4's estimate is 2.0-fold (0.30 log units) below it; the range from low to high includes it.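

In this assay, placing bromo instead of fluoro on the core of compound 3 gave a 1.2-fold lower number from compound 3 to compound 4 (0.07 log units; within the scatter), so on this core the change does not move the number by more than repeated measurements normally would. Set beside the earlier pair, the two steps cannot be told apart: the same change on two cores in this assay, a 2.6-fold lower number (0.42 log units; beyond the scatter) from compound 1 to compound 2 and a 1.2-fold lower number (0.07 log units; within the scatter) from compound 3 to compound 4, 2.2-fold (0.35 log units) apart, within the scatter of two such steps. Among these compounds, this shows that the results do not conflict with the change acting alike on both cores, but it does not show that the earlier step carries over, since only one of the two steps is beyond the scatter and two pairs are a thin basis for any rule.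

The compounds shown leave open how other groups would behave at the same place on the ring, for example an amine, a carboxylic acid or a nitrile in place of the bromo or fluoro. They also leave open whether a third core, such as one carrying a methoxy group in place of the trifluoromethyl group, would give a step closer to the first pair or the second.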